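This account rests on a few compounds, and the source may have more. Where it says the series, first, only, none or still open, it means among the compounds named here.

Compound 1 `N/C(=N\NC(=S)N1CCOCC1)c1ccccn1`: 66.7% in a functional assay on MCF7 cells (Homo sapiens) for cytotoxicity, read by MTT assay, with a stated time of 72 h, tested at 10 uM; a lower number here means less inhibition of growth, a higher number more inhibition of growth at the concentration tested
Compound 2 `N/C(=N\NC(=S)N1CCCCC1)c1ccccn1`: 53.1%
Compound 3 `Cc1cccc(/C(N)=N/NC(=S)N2CCOCC2)n1`: 39.1%

Among the three measured compounds, compound 1 stands highest in this assay, with compound 2 nearest and compound 3 furthest. Compound 4 `N/C(=N\NC(=S)N1CCOCC1)c1ccc(F)cn1` differs from compound 1 in one place: fluoro in place of hydrogen on an aromatic carbon. Neither measured step matches this change. The step of a number 13.6 percentage points lower from compound 1 to compound 2 (beyond the scatter) alters the thiocarbonyl-bound ring, and the step of a number 27.6 percentage points lower from compound 1 to compound 3 (beyond the scatter) adds a methyl on an aromatic carbon of the shared core at a different site from the fluoro. Both measured changes away from compound 1 lowered the number, so a modest drop is expected for compound 4, a number 9.7 percentage points lower from compound 1 to compound 4 (within the scatter), but a result within the scatter cannot be excluded. Compound 4 is therefore estimated at 57%, within 40% to 74%.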

Compound 4, percent growth inhibition at one concentration: 39.5%
Estimate against measurement, compound 4: 17.5 percentage points above, outside the stated range (below it).
By their numbers in this assay, from the lowest: compounds 3 and 4 (each within the scatter of the next); then compound 2; then compound 1.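

In this assay, fluoro in place of hydrogen on this aromatic carbon, two atoms from the ring nitrogen, gives a number 27.2 percentage points lower from compound 1 to compound 4 (beyond the scatter), so a single added heavy atom here moves the number beyond the scatter. With a number 27.6 percentage points lower from compound 1 to compound 3 (beyond the scatter), both aromatic-carbon replacements shown lower the number, at different sites. Nothing available explains why this fluoro change lowers the number.

On these data alone, whether chloro, methoxy or an amine on this same carbon would behave like fluoro remains open. So does whether fluoro would lower the number on compound 2, which carries piperidin-1-yl.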